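Swapping the benzyl substituent of a muscarinic modulator

The compounds below may be only part of what the source reports. "The series", "measured", "known", "first", "only" and "open" are said of these compounds alone.

Three compounds share a piperidine-carboxamide core with a sulfonyl-linked aromatic group on one side and an ethyl-substituted benzylic amide on the other. In a functional assay on CHO cells for positive allosteric modulation of muscarinic acetylcholine receptor M5 (Homo sapiens), read by calcium flux (a lower number here means a smaller maximal response, a higher number a larger maximal response), compound 3 `CCN(Cc1ccc(F)cc1)C(=O)C1CCN(S(=O)(=O)c2ccc3cn[nH]c3c2)CC1` gives 55%. Compound 1 `CCN(Cc1ccccc1)C(=O)C1CCN(S(=O)(=O)c2cccc3c2OCCO3)CC1` gives 53%, a value that lies within the usual scatter of the value for compound 3, so the two cannot be told apart. Compound 2 `CCN(C(=O)C1CCN(S(=O)(=O)c2ccc3c(c2)CCC3)CC1)[C@H](C)c1ccccc1` gives 97%, and this reading stands beyond the scatter above the value for compound 3, which makes compound 3 the second highest of the three numbers.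

Compound 4 `CCN(Cc1ccccc1OC)C(=O)C1CCN(S(=O)(=O)c2ccc3cn[nH]c3c2)CC1` has not been measured. It differs from compound 3 in one place: 2-methoxyphenyl in place of 4-fluorophenyl on a saturated chain carbon bound to an amide-type nitrogen. For the measured compounds named here, no measured pair shows this exchange, so there is no observed step to lean on. The two benzylic variants measured so far, compound 1 and compound 3, sit close together, which suggests that changes in this part of the molecule have been modest. The estimated step from compound 3 to compound 4 in this assay is a number 3 percentage points higher from compound 3 to compound 4 (within the scatter), expected to remain within the scatter. Compound 4 is therefore estimated at 58%, with a likely range from 35% to 80%.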

Compound 4, largest response reached (reported as percent of maximum), in percent of the reference or control that the assay uses: 92%
The estimate for compound 4 lay 34 percentage points below the measured number; the measured number lies above the stated range.
By their numbers in this assay, from the lowest: compounds 1 and 3 (each within the scatter of the next); then compounds 4 and 2 (each within the scatter of the next).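

In this assay, putting 2-methoxyphenyl in place of 4-fluorophenyl on a saturated chain carbon bound to an amide-type nitrogen gives a number 37 percentage points higher from compound 3 to compound 4 (beyond the scatter). For the compounds shown here, this is the first step here read between two compounds that differ in one place, and it shows that this exchange alone, with the rest of the molecule held constant, can shift the maximal response by a wide margin. No measurement shown here accounts for the rise.

The exchange removes the fluorine and adds the methoxy group in a single move, so the compounds shown leave open whether the methoxy group itself or its place on the ring matters. A 4-methoxyphenyl or a 2-fluorophenyl group on the same core would separate those two questions, and a 2-ethoxyphenyl group would test whether a longer chain on the oxygen keeps the response.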